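A few compounds are considered here, and "the series" means these few. Any claim that something is new, unique, unknown or untested is made for them only; others in the source may bear on it.

In a functional assay on HCT-116 cells (Homo sapiens) for antiproliferative activity, read by sulforhodamine B assay, with a stated time of 48 h (on this read-out higher numbers stand for weaker inhibition of growth and lower numbers for stronger inhibition of growth), the measured compounds so far:
- compound 1 `O=C(NCCCNc1cc(-c2cn(-c3ccccc3)nc2-c2cccc(O)c2)ccn1)Nc1ccc(F)cc1` gives 5820 nM
- compound 2 `O=C(NCCCNc1cc(-c2cn(-c3ccccc3)nc2-c2cccc(O)c2)ccn1)Nc1cccc(C(F)(F)F)c1` gives 6330 nM

Still unmeasured: compound 3 `COc1cccc(-c2nn(-c3ccccc3)cc2-c2ccnc(NCCCNC(=O)Nc3ccc(F)cc3)c2)c1`

Among the measured compounds shown here, compound 1 has only one measured neighbour, compound 2, and the two sit level within the scatter. Compound 3 departs from compound 1 at one place, hydroxy to methoxy, or 3-hydroxyphenyl to 3-methoxyphenyl, counted as methyl in place of hydrogen on an oxygen on an aromatic ring with methyl in place of hydrogen on an oxygen on an aromatic ring.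

For the measured compounds named here, only one measured step is available, a 1.1-fold higher number from compound 1 to compound 2 (0.04 log units; within the scatter), and it lies on an amide-type nitrogen rather than on this oxygen. It therefore bears on the new change only indirectly. Going by the values given here, it shows that one substituent swap elsewhere left the number in this assay unmoved, but no measured pair tests the oxygen itself. No direction can be drawn from these data, so the expectation is for no step beyond the scatter, with a wide margin for the untested position.

The expected step is a 1.1-fold higher number from compound 1 to compound 3 (0.05 log units; within the scatter) as an estimate. For compound 3 the estimated value is 6500 nM, with an expected range from 2500 nM to 17000 nM.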

Compound 3, concentration for total growth inhibition: 17000 nM
Compound 3: the middle estimate sits 2.6-fold (0.42 log units) below what was measured; low and high end bracket the measured number.
By their numbers in this assay, from the lowest: compounds 1 and 2 (each within the scatter of the next); then compound 3.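

In this assay, among the compounds shown here, the oxygen on the aromatic ring is the first place where a single change carries the number beyond the scatter: methyl in place of hydrogen there gives a 2.9-fold higher number from compound 1 to compound 3 (0.47 log units; beyond the scatter), while the one earlier swap, on an amide-type nitrogen, reads a 1.1-fold higher number from compound 1 to compound 2 (0.04 log units; within the scatter). The direction is toward weaker inhibition of growth, so this position responds to the addition of one carbon, although the step is modest and the hydroxy of compound 1 gives the lower number of this pair. Nothing measured here accounts for the step.

One pair cannot separate the effect of the added methyl from that of the lost hydrogen on this oxygen, and an ethoxy group, an amine or a carboxylic acid in place of the hydroxy would give further points at this position. As far as these compounds go, it also remains open whether methoxy in place of hydroxy gives a step of similar size when the amide-type nitrogen carries the 3-(trifluoromethyl)phenyl group of compound 2.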